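The compounds below may be only part of what the source reports. "The series", "measured", "known", "first", "only" and "open" are said of these compounds alone.

Compound 1 `C=CCn1c(=O)/c(=C\c2cccc(C)c2)[nH]c(=O)/c1=C\c1ccccc1OC` stands second highest of the three numbers in a functional assay on U-937 cells (Homo sapiens) for cytotoxicity, read by CCK-8 assay, with a stated time of 72 h (a lower number here means a stronger inhibitor, a higher number a weaker inhibitor), where compound 1 gives 5100 nM. Its nearest neighbour is compound 3 `C=CCn1c(=O)/c(=C\c2ccccc2F)[nH]c(=O)/c1=C\c1ccccc1OC`, which gives 5500 nM; the step of a 1.1-fold higher number from compound 1 to compound 3 (0.03 log units; within the scatter) lies within the scatter. Among the measured compounds shown here, compound 2 `COc1ccccc1/C=c1\c(=O)[nH]/c(=C/c2ccccc2Cl)c(=O)n1C` gives 100 nM, a much lower number, but no single-change step joins it to compound 1. The untested compound 4 `C=CCn1c(=O)/c(=C\c2cccc(Cl)c2)[nH]c(=O)/c1=C\c1ccccc1OC` differs from compound 1 by chloro in place of methyl on an aromatic carbon. No measured step alters a group on that ring in this way, and the one step shown stayed within the scatter, so the expected step of a 1.3-fold lower number from compound 1 to compound 4 (0.11 log units; within the scatter) is small, with no direction claimed beyond the scatter. Compound 4 is therefore estimated at 4000 nM, between 1500 nM and 11000 nM.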

Compound 4, half-maximal inhibitory concentration: 1200 nM
For compound 4 the middle estimate is 3.3-fold (0.52 log units) above the measured one; measured number below the stated range.
By their numbers in this assay, from the lowest: compound 2; then compound 4; then compounds 1 and 3 (each within the scatter of the next).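

The aryl group on this double-bonded chain carbon can shift the number after all: the earlier step there stayed within the scatter, but chloro in place of methyl gives a 4.3-fold lower number from compound 1 to compound 4 (0.63 log units; beyond the scatter) and lies beyond it. The 3-chlorophenyl group in place of 2-fluorophenyl gives a 4.6-fold lower number from compound 3 to compound 4 (0.66 log units; beyond the scatter), which points the same way. No evidence accompanies this result to account for it. Still open, as far as these compounds go, is how an amine or a carboxylic acid on that aromatic carbon would compare with chloro, and whether the chloro gain carries over to other variants of the shared core.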